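Acrylonitrile amides: naphthyl core with a dichlorobenzyl amide

The compounds below may be only part of what the source reports. "The series", "measured", "known", "first", "only" and "open" are said of these compounds alone.

Measured compounds:
compound 1, `COc1ccc(CNC(=O)/C(C#N)=C/c2cccc3ccccc23)cc1`: 14000 nM
compound 2, `COc1ccc(/C=C(\C#N)C(=O)NCc2ccc(Cl)c(Cl)c2)cc1`: 95000 nM

In a functional assay on SW480 cells (Homo sapiens) for inhibition, read by MTT assay, with a stated time of 72 h (on this read-out higher numbers stand for weaker inhibition of growth and lower numbers for stronger inhibition of growth), compound 1 gives 14000 nM and stands lowest of the two numbers; compound 2 gives 95000 nM, a higher number beyond the scatter. Compound 3, `N#C/C(=C\c1cccc2ccccc12)C(=O)NCc1ccc(Cl)c(Cl)c1`, keeps the core of compound 1 and differs by 3,4-dichlorophenyl in place of 4-methoxyphenyl on a saturated chain carbon bound to an amide-type nitrogen. Among the compounds with values here, no measured pair isolates this change, so the direction is open. The step of a 1.4-fold higher number from compound 1 to compound 3 (0.15 log units; within the scatter) is expected to be small, within or close to the scatter. Compound 3 is estimated at 20000 nM, with a range from 5000 nM to 80000 nM.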

Compound 3, concentration for 50% growth inhibition: 11000 nM
Estimate against measurement, compound 3: 1.8-fold (0.26 log units) above; low and high end bracket the measured number.
By their numbers in this assay, from the lowest: compounds 3 and 1 (each within the scatter of the next); then compound 2.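

In this assay, 3,4-dichlorophenyl in place of 4-methoxyphenyl on a saturated chain carbon bound to an amide-type nitrogen gives a 1.3-fold lower number from compound 1 to compound 3 (0.10 log units; within the scatter), so on the core of compound 1 the two aryl groups cannot be told apart at this position. Within the data shown here, this single step is the only direct reading of the position, and it holds for this core alone. No measurement at hand explains the result.

As far as these compounds go, whether an amine or a carboxylic acid in place of the 3,4-dichlorophenyl would keep the number in this range remains open. From the compounds shown here alone, a longer chain to the amide nitrogen is equally open.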